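Changing the Ring on the Double-Bonded Chain

The source may report more compounds than this note shows. Statements on the series, on what has been measured and on what is new or still open speak of the compounds shown alone.

Measured so far in a functional assay on 786-0 cells (Homo sapiens) for inhibition; on this read-out lower numbers stand for stronger inhibition of growth and higher numbers for weaker inhibition of growth:
- compound 1 `COc1cc(/C=C/C(=O)c2cccc(-n3cc(-c4ccc(Cl)cc4)[nH]c3=O)c2)ccc1O`: 2070 nM
- compound 2 `COc1cc(/C=C/C(=O)c2cccc(-n3cc(-c4ccccc4)[nH]c3=O)c2)ccc1O`: 1350 nM

Compound 1 gives the highest of the two numbers in this assay. Among the measured compounds shown here, its nearest neighbour is compound 2, and the one measured step, a 1.5-fold lower number from compound 1 to compound 2 (0.19 log units; within the scatter), is within the scatter, so the two compounds cannot be told apart on this read-out.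

Compound 3 `O=C(/C=C/c1cccc(O)c1)c1cccc(-n2cc(-c3ccc(Cl)cc3)[nH]c2=O)c1` differs from compound 1 in one place: 3-hydroxyphenyl in place of 4-hydroxy-3-methoxyphenyl on a double-bonded chain carbon bound to a double-bonded chain carbon. This change sits on a part of the molecule that the measured step does not touch; that step concerns only a substituent on a different aromatic ring. For the measured compounds named here, no measured step therefore bears directly on the change from compound 1 to compound 3, and the data give no basis for expecting a shift in either direction beyond the scatter.

The estimate for compound 3 is accordingly anchored on compound 1, with a wide range: compound 3 is expected to give 2500 nM, between 800 nM and 8000 nM, which corresponds to an expected step of a 1.2-fold higher number from compound 1 to compound 3 (0.08 log units; within the scatter).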

Compound 3, concentration for 50% growth inhibition: 1570 nM
Compound 3: the middle estimate sits 1.6-fold (0.20 log units) above what was measured, within the range that was stated.
By their numbers in this assay, from the lowest: compounds 2, 3 and 1 (each within the scatter of the next).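

In this assay, among the compounds shown here, the first change at this position gives a 1.3-fold lower number from compound 1 to compound 3 (0.12 log units; within the scatter), so compound 1 and compound 3 cannot be told apart on this read-out. The group that enters, 3-hydroxyphenyl, has 7 heavy atoms and 1 hydrogen-bond acceptor, against 9 heavy atoms and 2 hydrogen-bond acceptors in the 4-hydroxy-3-methoxyphenyl group that leaves, so this smaller group on a double-bonded chain carbon bound to a double-bonded chain carbon produces no readable shift in growth inhibition. Nothing is available to explain this result.

All three compounds shown still carry a hydroxy group on this ring, so the result says nothing about a plain phenyl ring here, or about a ring bearing an amine or a carboxylic acid instead. Going by these compounds, it also remains open whether the same exchange would give a similarly small step on compound 2, which has hydrogen in place of chloro, since this one comparison covers only the chloro-bearing compounds.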